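A few compounds are considered here, and "the series" means these few. Any claim that something is new, unique, unknown or untested is made for them only; others in the source may bear on it.

Measured compounds:
- compound 1 `COC(=O)c1c(-c2ccc(OCc3ccccc3)cc2)oc2ccc(OC)cc2c1=O`: 15.6 ug/mL
- compound 2 `COC(=O)c1c(-c2ccc(O)cc2)oc2ccccc2c1=O`: > 25 ug/mL, a limit of the assay

In a functional assay on HT-29 cells (Homo sapiens) for cytotoxicity, read by MTT assay, with a stated time of 6 days (on this read-out lower numbers stand for an effect already at smaller amounts and higher numbers for an effect only at larger amounts of compound), compound 2 stands only at a limit, > 25 ug/mL, so no number is known for it.

Compound 3 `COC(=O)c1c(-c2ccc(O)cc2)oc2ccc(OC)cc2c1=O` has not yet been measured. It differs from compound 2 by a methoxy in place of hydrogen on an aromatic carbon, (methoxy in place of hydrogen on an aromatic carbon). This carbon belongs to a six-membered aromatic ring of carbon only, part of a fused or bridged system of two rings.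

Going by the values given here, no measured step shows what such a change does in this assay. Among the compounds with values here, the only number at hand is that of compound 1, 15.6 ug/mL, so a small shift toward lower numbers is expected, or none beyond the scatter.

The expected step is an at least 1.1-fold lower number from compound 2 to compound 3 (0.05 log units; that floor lies within the scatter). For compound 3 the estimated value is 22 ug/mL, with an expected range from 10 ug/mL to 50 ug/mL.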

Compound 3, concentration for half-maximal effect: > 25 ug/mL
Compound 3: no number, only a limit; the forecaster's own chance of this, stated with the estimate: 45%; middle value at least 1.1-fold (0.05 log units) away from the limit.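

In this assay, compound 3 gives > 25 ug/mL, which is a limit of the assay and not a number. Adding the methoxy on this aromatic carbon therefore yields no readable value, and the step it makes cannot be read, because both of its ends sit at the same limit: the limit of > 25 ug/mL in this assay, at which 2 of the 3 values shown sit. The compound does add one readable comparison: hydrogen in place of benzyl on the oxygen gives an at least 1.6-fold higher number from compound 1 to compound 3 (0.20 log units; that floor lies within the scatter), so the change is bounded on one side only, and that bound alone does not show a shift beyond the scatter.

From the compounds shown here alone, how far compound 2 and compound 3 lie past the limit stays open. So does whether an amine in place of the methoxy, or a propyl chain in place of the benzyl on the oxygen, would give a readable number in this assay.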